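From trifluoromethyl to methoxy: a solubility estimate

The source may hold more compounds than are shown below. What is called first, only, known or untested is meant among the compounds shown, and "the series" means these compounds.

In a physicochemical assay for solubility (a higher number here means a more soluble compound, a lower number a less soluble compound), compound 1 (`C[C@H](Oc1ccc(S(C)(=O)=O)cc1C(=O)N1Cc2ccccc2C1)C(F)(F)F`) gives < 1 ug/mL and that reading is a limit of the assay, not a number. Among the measured compounds shown here, compound 2 (`C[C@H](Oc1ccc(S(C)(=O)=O)cc1C(=O)N1Cc2ccc(C(F)(F)F)cc2C1)C(F)(F)F`) gives 1 ug/mL as the only true number so far, so it has nothing measured to be ranked against. Any estimate here must also reckon with the limit of < 1 ug/mL in this assay, at which 1 of the 2 values shown sits, as a real outcome. Compound 3 (`COc1ccc2c(c1)CN(C(=O)c1cc(S(C)(=O)=O)ccc1O[C@@H](C)C(F)(F)F)C2`) carries methoxy in place of trifluoromethyl on an aromatic carbon, on a ring that is otherwise unchanged. For the measured compounds named here, only one step has been measured (a number no lower from compound 1 to compound 2 (the limit leaves the size open)) and it has no readable size, so it offers little guidance and no change beyond the usual scatter is expected. The expected change (a 1.5-fold higher number from compound 2 to compound 3 (0.18 log units; within the scatter)) is only an estimate and stays within that scatter. For compound 3 the estimated solubility is 1.5 ug/mL within an expected range of 0.7 ug/mL to 5 ug/mL and the result may yet arrive as a limit.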

Compound 3, solubility: 46 ug/mL
Compound 3: middle estimate off by 31-fold (1.49 log units), on the low side; measured number outside the range, above it.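

In this assay, this one aromatic carbon proves far from neutral: methoxy in place of trifluoromethyl gives a 46-fold higher number from compound 2 to compound 3 (1.66 log units; beyond the scatter). Methoxy in place of hydrogen on the same carbon gives an at least 46-fold higher number from compound 1 to compound 3 (1.66 log units; beyond the scatter), so compound 3 stands clear of both earlier compounds, something the earlier step with no readable size could not show. Compound 1 gives a limit, not a number, so the second step stays open at one end: the limit of < 1 ug/mL in this assay, at which 1 of the 3 values shown sits.

Going by these compounds, what an amine, a hydroxyl or a longer chain such as ethoxy would give on this same aromatic carbon stays open. The reason for the jump also stays open: three compounds show its size, not its cause.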